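Fluoro for Trifluoromethyl: Cytotoxicity Notes on Four Compounds

The source may report more compounds than this note shows. Statements on the series, on what has been measured and on what is new or still open speak of the compounds shown alone.

Measured so far:
- Compound 1 `CN1C/C(=C\c2ccncc2)C(=O)/C(=C/c2ccccc2F)C1`: in a functional assay on SMMC-7721 cells (Homo sapiens) for cytotoxicity, read by MTT assay, with a stated time of 24 h (on this read-out lower numbers stand for stronger inhibition and higher numbers for weaker inhibition), compound 1 gives 7000 nM.
- Compound 2 `CN1C/C(=C\c2ccncc2)C(=O)/C(=C/c2ccccc2C(F)(F)F)C1`: in this assay compound 2 gives 4100 nM.
- Compound 3 `O=C1/C(=C/c2cccnc2)CN(S(=O)(=O)c2ccc(C(F)(F)F)cc2)C/C1=C\c1ccccc1F`: in this assay compound 3 gives 7900 nM.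

Compounds 1 and 2 share a core and differ by one change, (fluoro in place of trifluoromethyl on an aromatic carbon). The step it made is a 1.7-fold higher number from compound 2 to compound 1 (0.23 log units; within the scatter). Compound 3 carries a different core; the difference between the two cores is not broken down here. The values of compound 3 and compound 2 lie within the scatter of each other, as do those of compound 3 and compound 1.

Compound 4 `O=C1/C(=C/c2cccnc2)CN(S(=O)(=O)c2ccc(F)cc2)C/C1=C\c1ccccc1F` is not yet measured. It differs from compound 3 by fluoro in place of trifluoromethyl on an aromatic carbon. This is the same kind of change as that from compound 2 to compound 1, not the same: there the fluoro sits ortho to a large group, here para to a large group.

The step expected in this assay is a 1.2-fold higher number from compound 3 to compound 4 (0.08 log units; within the scatter), resting on the earlier step of a 1.7-fold higher number from compound 2 to compound 1 (0.23 log units; within the scatter), which stayed within the scatter. Compound 4 is thus estimated at 9500 nM, with a range from 4000 nM to 22000 nM.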

Compound 4, half-maximal inhibitory concentration: 9900 nM
Beside the measured number, compound 4's estimate is 1.0-fold (0.02 log units) below it, and the stated range covers the measured number.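

In this assay, fluoro in place of trifluoromethyl, here 4-(trifluoromethyl)phenyl to 4-fluorophenyl, gives a 1.3-fold higher number from compound 3 to compound 4 (0.10 log units; within the scatter), so on this second core too the change stays inside the usual scatter. Within the data shown here, this does not show that the change has a real effect that travels from core to core: neither step can be told apart from repeat noise, so their agreement means only that the change stayed small on both cores, and two cores are a thin basis for any rule about the series. Within those limits, the change can be carried between these two cores without a step that can be told from the scatter, and the two steps do not differ: the same change on two cores in this assay, a 1.7-fold higher number (0.23 log units; within the scatter) from compound 2 to compound 1 and a 1.3-fold higher number (0.10 log units; within the scatter) from compound 3 to compound 4, 1.4-fold (0.13 log units) apart, within the scatter of two such steps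

Still open, going by these compounds, is whether another group at this place, such as an amine, a carboxylic acid or a longer alkyl chain, would move the number beyond the scatter. Also open, on these data alone, is how the same exchange reads on a third core, or in a cell line other than the one used here.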